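The source may hold more compounds than are shown below. What is called first, only, known or untested is meant among the compounds shown, and "the series" means these compounds.

Measured in an ADME assay on microsomes from liver (Mus musculus) for metabolic stability, read by LC-MS, using NADPH, with a stated time of 15 min, tested at 1 uM; on this read-out lower numbers stand for slow clearance and higher numbers for fast clearance:
- compound 1 `C[C@@H]1CN(c2sc(C(F)(F)F)nc2-c2nc3cc(OCCO)ccc3[nH]2)CCN1C(=O)Cn1cnc2cccnc21` gives 31 mL.min-1.g-1
- compound 2 `C[C@@H]1CN(c2sc(C(F)(F)F)nc2-c2nc3ccccc3[nH]2)CCN1C(=O)Cn1cccn1` gives 218 mL.min-1.g-1
- compound 3 `Cc1nc(C)n(CC(=O)N2CCN(c3sc(C(F)(F)F)nc3-c3nc4ccc(C5CCOCC5)cc4[nH]3)C[C@H]2C)n1` gives 46 mL.min-1.g-1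

Compound 3 stands second highest of the three numbers in this assay. Its nearest neighbour is compound 1, whose number sits within the usual scatter of that of compound 3, so no order can be read between them. Its furthest neighbour is compound 2, whose number lies beyond the scatter above that of compound 3.

Compound 4 `Cc1nc(C)n(CC(=O)N2CCN(c3sc(C(F)(F)F)nc3-c3nc4ccccc4[nH]3)C[C@H]2C)n1` is not yet measured. It differs from compound 3 in one place: hydrogen in place of oxan-4-yl on an aromatic carbon. Among the compounds with values here, no step between two measured compounds covers this change alone, so its size cannot be read off directly. Of the measured set, compound 2 carries no group at that place and gives 218 mL.min-1.g-1, while compound 3, carrying the oxan-4-yl group there, gives 46 mL.min-1.g-1; these two differ also in the heterocycle on the amide, so only their two values are noted. For compound 4 a moderate rise is expected, a step of a 2.1-fold higher number from compound 3 to compound 4 (0.31 log units; beyond the scatter) that probably edges beyond the scatter. The estimate for compound 4 in this assay is 95 mL.min-1.g-1, with a range from 45 mL.min-1.g-1 to 200 mL.min-1.g-1.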

Compound 4, intrinsic clearance in microsomes: 21 mL.min-1.g-1
Compound 4: the middle estimate sits 4.5-fold (0.66 log units) above what was measured; the whole stated range lies above it.
By their numbers in this assay, from the lowest: compounds 4, 1 and 3 (each within the scatter of the next, the first and the last beyond it); then compound 2.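

In this assay, hydrogen in place of oxan-4-yl on the aromatic carbon gives a 2.2-fold lower number from compound 3 to compound 4 (0.34 log units; beyond the scatter), so in this pair the bare aromatic carbon goes with the lower clearance, and oxan-4-yl is not needed there for a low number. With hydrogen at that place in both compounds, 3,5-dimethyl-1H-1,2,4-triazol-1-yl in place of 1H-pyrazol-1-yl gives a 10-fold lower number from compound 2 to compound 4 (1.02 log units; beyond the scatter), so the heterocycle on the amide accounts for a far larger shift in this read-out than the group on the aromatic carbon does. No measurement at hand explains either step.

On these data alone, whether removing oxan-4-yl gives a similar step with 1H-pyrazol-1-yl on the amide remains open. Also open, as far as these compounds go, is how a fluorine atom, a methoxy group or an amine on that aromatic carbon compares with hydrogen.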